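Methyl on the aromatic oxygen: two pairs compared

The source may report more compounds than this note shows. Statements on the series, on what has been measured and on what is new or still open speak of the compounds shown alone.

Compound 1 `O=C(Nc1ccccc1)c1cc(Br)ccc1O` and compound 2 `COc1ccc(Br)cc1C(=O)Nc1ccccc1` form the first pair. In an assay for inhibition of HSP60/HSP10 (Homo sapiens), with a stated time of 60 min (on this read-out lower numbers stand for stronger inhibition and higher numbers for weaker inhibition), compound 1 is reported only as a limit of the assay, > 100000 nM. Compound 2 is likewise reported only as a limit in this assay, > 100000 nM. The change between them is methyl in place of hydrogen on an oxygen on an aromatic ring, and the step it made, a step that the two limits leave unreadable from compound 1 to compound 2, cannot be sized, since the limit of > 100000 nM in this assay, at which 2 of the 3 values shown sit, holds both ends of the pair.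

Compound 3 `O=C(Nc1ccc(Sc2nc3ccccc3s2)cc1)c1cc(Br)cc(Br)c1O` carries a larger core; the difference between this core and that of compound 1 is not broken down here. In this assay, among the compounds with values here, compound 3 gives 4700 nM, the only number among the three values shown.

Compound 4 `COc1c(Br)cc(Br)cc1C(=O)Nc1ccc(Sc2nc3ccccc3s2)cc1` is compound 3 with methyl in place of hydrogen on an oxygen on an aromatic ring. The place of the change reads word for word as in the first pair, so the same change is made twice in the series. The measured pair gives no readable size for it, and no other shown data bear on this change, so the step from compound 3 to compound 4 is estimated with wide bounds, a 5.3-fold higher number from compound 3 to compound 4 (0.73 log units; beyond the scatter), centred on a loss that stays short of the limit. For compound 4 the expected value in this assay is 25000 nM, with a range from 5000 nM to 100000 nM, and a real chance that only a limit is reported.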

Compound 4, half-maximal inhibitory concentration: > 100000 nM
Compound 4: a limit, no number; the forecaster's own chance of this, stated with the estimate: 35%; at least 4.0-fold (0.60 log units) between middle value and limit.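

In this assay, methyl in place of hydrogen on an oxygen on an aromatic ring, which reads as hydroxy to methoxy, gives an at least 21-fold higher number from compound 3 to compound 4 (1.32 log units; beyond the scatter), so on the larger core the measured number belongs to the hydroxy compound alone. Going by these compounds, compound 4 is reported only as a limit, > 100000 nM, so this step is a minimum and its full size stays unknown. The series therefore shows a large loss on one core but does not show that the change acts alike on both cores, because the step on the core of compound 1 cannot be read and no comparison of the two step sizes is possible: the limit of > 100000 nM in this assay, at which 3 of the 4 values shown sit.

On these data alone, compounds 1 and 3 differ in more than one place, so it remains open which part of the larger core goes with the number seen for compound 3. As far as these compounds go, it also remains open whether the loss on that core is specific to methyl or extends to other replacements for the hydroxy, such as an amine in its place or ethyl, a longer chain, on the same oxygen.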